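The source may hold more compounds than are shown below. What is called first, only, known or untested is meant among the compounds shown, and "the series" means these compounds.

Values in an ADME assay on WI-38 cells (Homo sapiens) for cytotoxicity, read by MTT assay, with a stated time of 72 h; on this read-out lower numbers stand for stronger inhibition and higher numbers for weaker inhibition:
Compound 1 `O=C(CCc1cccc2c1B(O)OC2)Nc1cccc(I)c1`: 71000 nM
Compound 2 `COc1cc(OC)cc(-c2cccc(NC(=O)CCc3cccc4c3B(O)OC4)c2)c1`: 1700 nM
Compound 3 `CSc1ccc(-c2cccc(NC(=O)CCc3cccc4c3B(O)OC4)c2)cc1`: 3800 nM

Compound 3 is the second highest of these three numbers, lying much nearer to compound 2 than to compound 1. The next compound to be tested is compound 4 `CC(=O)c1cccc(-c2cccc(NC(=O)CCc3cccc4c3B(O)OC4)c2)c1`, which keeps the shared core and has 3-acetylphenyl in place of 4-(methylsulfanyl)phenyl on an aromatic carbon.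

Two kinds of measured step bear on this change. The large ones, a 42-fold lower number from compound 1 to compound 2 (1.62 log units; beyond the scatter) and a 19-fold lower number from compound 1 to compound 3 (1.27 log units; beyond the scatter), both replace iodo with a substituted phenyl group, so they say little about exchanging one such group for another. Among the compounds with values here, the closer precedent is the only phenyl-for-phenyl exchange measured so far, a modest step of a 2.2-fold higher number from compound 2 to compound 3 (0.35 log units; beyond the scatter). One such exchange does not establish a direction. In this assay, the change is therefore expected to stay small, with no step beyond the scatter as the likeliest outcome. The expected step is a 1.3-fold lower number from compound 3 to compound 4 (0.10 log units; within the scatter). For compound 4, the estimated value is 3000 nM, with an expected range of 1300 nM to 7500 nM.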

Compound 4, half-maximal inhibitory concentration: 2200 nM
Compound 4: middle estimate off by 1.4-fold (0.13 log units), on the high side, and the stated range covers the measured number.
By their numbers in this assay, from the lowest: compounds 2, 4 and 3 (each within the scatter of the next, the first and the last beyond it); then compound 1.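

In this assay, 3-acetylphenyl gives a 1.7-fold lower number from compound 3 to compound 4 (0.24 log units; within the scatter) and a 1.3-fold higher number from compound 2 to compound 4 (0.11 log units; within the scatter), so this group cannot be told apart from either 4-(methylsulfanyl)phenyl or 3,5-dimethoxyphenyl, even though those two groups are themselves separated by a modest step just beyond the scatter. With a 32-fold lower number from compound 1 to compound 4 (1.51 log units; beyond the scatter), a third substituted phenyl group in place of iodo gives a large step of the same order as the first two, this time with a carbonyl-bearing group that contains no sulfur, so among compounds 1 to 4 the replacement of iodo accounts for far more of the spread than the choice of phenyl group does. Nothing available explains either the large steps from iodo or the closeness of the phenyl exchanges.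

As far as these compounds go, it remains open whether an amine or a carboxylic acid on the entering phenyl ring would stay within this narrow band in this assay. The same applies to a longer chain in place of the phenyl group, and to 4-acetylphenyl as a direct comparison with compound 4.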